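From nitrile to trifluoromethyl in a growth inhibition series

A few compounds are considered here, and "the series" means these few. Any claim that something is new, unique, unknown or untested is made for them only; others in the source may bear on it.

Compound 1 `O=C(Nc1nc2ccc([N+](=O)[O-])cc2s1)c1ccc(C(F)(F)F)cc1` gives 860 nM
Compound 2 `Cc1cc(C)c2sc(NC(=O)c3ccc(C#N)cc3)nc2c1` gives 290 nM

In a functional assay on MDA-MB-231 cells (Homo sapiens) for inhibition (a higher number here means a weaker inhibitor of growth, a lower number a stronger inhibitor of growth), compound 2 (290 nM) has the lower of the two numbers, and its gap to compound 1 (860 nM) lies beyond the usual scatter. These two compounds differ in more than one place, so the gap cannot be tied to any single group.

Compound 3 `Cc1cc(C)c2sc(NC(=O)c3ccc(C(F)(F)F)cc3)nc2c1` has not yet been measured. It keeps the core of compound 2 but carries trifluoromethyl in place of cyano on an aromatic carbon, para to a large group (trifluoromethyl in place of cyano on an aromatic carbon). Within the data shown here, no measured pair isolates this exchange, so the expectation remains loose. Among the measured compounds shown here, the only hint comes from compound 1 (860 nM), which carries trifluoromethyl and has the higher number, although its core differs as well. A modest rise in the number is therefore expected in this assay and may not clear the scatter. The estimated change is a 1.4-fold higher number from compound 2 to compound 3 (0.14 log units; within the scatter) (an uncertain figure). Compound 3 is expected at 400 nM (estimated range 140 nM to 1150 nM).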

Compound 3, concentration for 50% growth inhibition: 290 nM
Beside the measured number, compound 3's estimate is 1.4-fold (0.14 log units) above it; measured number inside the range.
By their numbers in this assay, from the lowest: compounds 2 and 3 (each within the scatter of the next); then compound 1.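

In this assay, the exchange of cyano for trifluoromethyl on an aromatic carbon, para to a large group, gives no change at the digits printed from compound 2 to compound 3 (within the scatter). Among these compounds, this is the first reading of the exchange on its own: trifluoromethyl had until now stood only on the core of compound 1, whereas here it sits on the core shared by compound 2 and compound 3, and the number holds with the hydrogen-bond acceptor of cyano gone, so that acceptor is not needed at this position to keep the number in this assay. No measurement here bears on why the two groups read alike.

Only these two groups are shown at this aromatic carbon, so it remains open whether an amine, a carboxylic acid or a longer chain there would hold the number or shift it. On these data alone, it also remains open whether the same exchange would read alike on the core of compound 1, and what replacing either methyl group on the shared core with hydrogen would do to growth inhibition in these cells.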